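The source may report more compounds than this note shows. Statements on the series, on what has been measured and on what is new or still open speak of the compounds shown alone.

Measured compounds in an assay on H4 cells for inhibition of Fatty-acid amide hydrolase 1 (Homo sapiens); a lower number here means a stronger inhibitor, a higher number a weaker inhibitor: compound 1 `CCCCCCCOc1ccc(NC(=O)Oc2ccccc2F)cc1` gives 28 nM; compound 2 `CCCCCCCCOc1ccc(NC(=O)Oc2ccccc2F)cc1` gives 19 nM; compound 3 `CCCCOc1ccc(C(CC)NC(=O)Oc2ccccc2F)cc1` gives 7.7 nM.

Compound 3 is the strongest inhibitor of the three, since its gap to compound 2 and to compound 1 lies beyond the scatter. Compound 4 `CCCCOc1ccc(C(CC)NC(=O)Oc2ccc(F)cc2)cc1` is built from compound 3 by one change: 4-fluorophenyl in place of 2-fluorophenyl on an oxygen next to a carbonyl group. The only measured step, a 1.5-fold lower number from compound 1 to compound 2 (0.17 log units; within the scatter), concerns the chain on the other side of the core and says nothing about moving the fluorine on the aryl carbamate ring, so no shown step bears on this change. Compound 4 is therefore expected to stay close to compound 3, with an estimated step of a 1.4-fold higher number from compound 3 to compound 4 (0.15 log units; within the scatter) in this assay. The estimate for compound 4 is 11 nM, between 3 nM and 40 nM.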

Compound 4, half-maximal inhibitory concentration: 12 nM
Compound 4: the middle estimate sits 1.1-fold (0.04 log units) below what was measured; the measured number falls inside the stated range.
By their numbers in this assay, from the lowest: compounds 3, 4, 2 and 1 (each within the scatter of the next, the first and the last beyond it).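

In this assay, exchanging 2-fluorophenyl for 4-fluorophenyl on the oxygen next to a carbonyl group gives a 1.6-fold higher number from compound 3 to compound 4 (0.19 log units; within the scatter), so the two fluorophenyl groups cannot be told apart at this place. Going by these compounds alone, the earlier step changed only a saturated chain, so this is the first view of how this aryl group tolerates change. Nothing measured here offers an explanation for this result. Still open, on these data alone, is whether the fluorine matters at all: plain phenyl, or chlorine in place of fluorine, would test that.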